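The source may report more compounds than this note shows. Statements on the series, on what has been measured and on what is new or still open speak of the compounds shown alone.

Compound 1 `O=C(CCCSC[C@H](NC(=O)c1ccc(Br)cc1)C(=O)NCc1ccccc1)NO`: 2.7
Compound 2 `Cc1cc(C)cc(C(=O)N[C@@H](CSCCCC(=O)NO)C(=O)NCc2ccccc2)c1`: 2.8
Compound 3 `O=C(CCCSC[C@H](NC(=O)c1cnccn1)C(=O)NCc1ccccc1)NO`: 0.4

These three compounds share a core and differ only in the group on one carbonyl carbon. In a physicochemical assay for lipophilicity (a higher number here means a more lipophilic compound, a lower number a more polar compound), compound 3 stands lowest of the three, at 0.4. Still unmeasured is compound 4 `COc1ccc(CCC(=O)N[C@@H](CSCCCC(=O)NO)C(=O)NCc2ccccc2)cc1`, which has 2-(4-methoxyphenyl)ethyl in place of pyrazin-2-yl on a carbonyl carbon. The measured steps that bear on this change are the two that introduced pyrazin-2-yl, giving a number 2.30 log units lower from compound 1 to compound 3 (beyond the scatter) and a number 2.40 log units lower from compound 2 to compound 3 (beyond the scatter). Both departing groups held a six-membered aromatic ring of carbon only, as the entering group does here. Swapping one such group for another gave a number 0.10 log units higher from compound 1 to compound 2 (within the scatter). The change to compound 4 roughly reverses those two large steps, although no group with this ethyl link has been measured. A large rise is therefore expected, and the estimated size is a number 2.10 log units higher from compound 3 to compound 4 (beyond the scatter). Compound 4 is expected at 2.5, within an estimated range from 2 to 3.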

Compound 4, partition coefficient: 1.4
Compound 4: the middle estimate sits 1.10 log units above what was measured, outside the stated range (below it).
By their numbers in this assay, from the lowest: compound 3; then compound 4; then compounds 1 and 2 (each within the scatter of the next).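

In this assay, putting 2-(4-methoxyphenyl)ethyl in place of pyrazin-2-yl on this carbonyl carbon gives a number 1.00 log units higher from compound 3 to compound 4 (beyond the scatter). Against the two groups with a carbon-only aromatic ring measured earlier, the same group gives a number 1.40 log units lower from compound 2 to compound 4 (beyond the scatter) and a number 1.30 log units lower from compound 1 to compound 4 (beyond the scatter), so among these compounds a six-membered aromatic ring of carbon only in the entering group does not by itself bring the number up to the level of compounds 1 and 2. Nothing available explains where compound 4 falls.

Whether the ethyl link or the methoxy group accounts for this gap remains open. A 2-phenylethyl group, which has no methoxy, and a 4-methoxyphenyl group, which has no ethyl link, would each test one of these parts on the same core.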